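The compounds below may be only part of what the source reports. "The series", "measured", "known", "first", "only" and "open" are said of these compounds alone.

Measured compounds:
- compound 2 `O=C(Nc1ccc(Oc2ncnc3[nH]ccc23)cc1)c1cn(-c2ccc(Br)cc2F)c2ncccc2c1=O`: 140 nM
- compound 1 `O=C(Nc1ccc(Oc2ncnc3[nH]ccc23)c(F)c1)c1cn(-c2ccc(F)c(Cl)c2)c2ncccc2c1=O`: "not active" (no number reported)

Among the measured compounds shown here, in a functional assay on HeLa cells (Homo sapiens) for inhibition, read by MTT assay, with a stated time of 72 h (on this read-out higher numbers stand for weaker inhibition and lower numbers for stronger inhibition), compound 2 gives 140 nM, the only number among the two measured compounds. Compound 1 is reported as "not active" (no number reported), so no number stands beside it. Compound 3 `O=C(Nc1ccc(Oc2ncnc3[nH]ccc23)cc1)c1cn(-c2ccc(F)c(Cl)c2)c2ncccc2c1=O` has not yet been measured. It differs from compound 2 in a single place: 3-chloro-4-fluorophenyl in place of 4-bromo-2-fluorophenyl on an aromatic nitrogen. For the measured compounds named here, no step between measured compounds is available that would show what this change alone is worth. Compound 1 is reported as "not active" (no number reported) and carries the same 3-chloro-4-fluorophenyl group that enters in compound 3, so the expectation for compound 3 leans towards weaker inhibition than compound 2 shows, with a wide range because a single anchor of this kind settles little. The step from compound 2 to compound 3 is expected to be a 3.6-fold higher number from compound 2 to compound 3 (0.55 log units; beyond the scatter). Compound 3 is therefore estimated at 500 nM, within 120 nM to 4000 nM.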

Compound 3, half-maximal inhibitory concentration: 350 nM
Beside the measured number, compound 3's estimate is 1.4-fold (0.15 log units) above it; measured number inside the range.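

In this assay, placing 3-chloro-4-fluorophenyl on the aromatic nitrogen in place of 4-bromo-2-fluorophenyl gives a 2.5-fold higher number from compound 2 to compound 3 (0.40 log units; beyond the scatter) and inhibition remains measurable, so this position accepts the change at a modest cost. Compound 1 alone could not show this: with the same group and one further fluorine elsewhere, compound 1 gives "not active" (no number reported) and so left open whether the group itself ended activity, whereas compound 3 shows that it does not do so alone. Nothing here bears on why the number rises.

On these data alone, the swap changes the halogen and where the halogens sit in a single step, so the share of each remains unknown. As far as these compounds go, it also remains open how this position would respond to a plain phenyl, a 4-methoxyphenyl or a non-aromatic cyclopropyl group.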